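A few compounds are considered here, and "the series" means these few. Any claim that something is new, unique, unknown or untested is made for them only; others in the source may bear on it.

Measured so far in a functional assay on HT-29 cells (Homo sapiens) for inhibition, read by MTT assay, with a stated time of 72 h; a lower number here means a stronger inhibitor, a higher number a weaker inhibitor:

compound 1, `Cc1ccc2c(c1)/C(=c1/sc(=Cc3ccc(C=O)c(C=O)c3)c(=O)n1CCN(C)C)C(=O)N2`: 1030 nM
compound 2, `CCN(CC)CCCn1c(=O)c(=Cc2cc(OC)c(OC)c(OC)c2)s/c1=C1\C(=O)Nc2ccc(C)cc21`: > 200000 nM
compound 3, `CN(C)CCn1c(=O)c(=Cc2ccc(F)cc2F)s/c1=C1\C(=O)Nc2cc(F)ccc21`: 6460 nM

Compound 2 stands apart from the other two. Its entry in this assay is a limit of the assay and not a number: the limit of > 200000 nM in this assay, at which 1 of the 3 values shown sits. Within the data shown here, compound 1 and compound 3 both give numbers inside the working range, but no single-point step between any two of the three is available, as each differs from the others in more than one place.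

Compound 4, `CCN(CC)CCCn1c(=O)c(=Cc2ccc(O)cc2)s/c1=C1\C(=O)Nc2ccc(C)cc21`, has not yet been measured in this assay. It keeps the core and the chain of compound 2 and differs in one place: 4-hydroxyphenyl in place of 3,4,5-trimethoxyphenyl on a double-bonded chain carbon bound to an aromatic carbon. Among the measured compounds shown here, no measured pair shows this change, so its size is open. Since compound 2 sits at a limit, any real number for compound 4 would register as a gain, while a second limit remains possible. The expectation leans toward a number, given that compound 1 at 1030 nM and compound 3 at 6460 nM show the series does yield measurable values. For compound 4 the estimate is 50000 nM, with a range from 5000 nM to 200000 nM. The expected step is an at least 4.0-fold lower number from compound 2 to compound 4 (0.60 log units; beyond the scatter), a gain beyond the scatter if the limit is taken at face value.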

Compound 4, half-maximal inhibitory concentration: 770 nM
Compound 4: the middle estimate sits 65-fold (1.81 log units) above what was measured; the whole stated range lies above it.
By their numbers in this assay, from the lowest: compounds 4 and 1 (each within the scatter of the next); then compound 3. At a limit, above all of these: compound 2.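

Among these compounds, with the core and chain of compound 2 held fixed, the group on the double-bonded chain carbon bound to an aromatic carbon is the first single change that can be read in this assay: 4-hydroxyphenyl in place of 3,4,5-trimethoxyphenyl gives an at least 250-fold lower number from compound 2 to compound 4 (2.41 log units; beyond the scatter). This position can therefore move the series from a limit to a number within the working range, and the step gives only a minimum size. The entry for compound 2 is a limit of the assay and not a number: the limit of > 200000 nM in this assay, at which 1 of the 4 values shown sits.

Going by these compounds, it remains open whether the step follows the hydroxyl group or the loss of the methoxy groups; the change alters both at once. A 4-methoxyphenyl or an unsubstituted phenyl group at this place, on the same core and chain, would separate the two.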